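This account rests on a few compounds, and the source may have more. Where it says the series, first, only, none or still open, it means among the compounds named here.

Compound 1 `O=c1[nH]/c(=N\OCCOc2ccccc2)ccn1[C@@H]1O[C@H](COP(=O)(O)OP(=O)(O)OP(=O)(O)O)[C@@H](O)[C@H]1O` and compound 2 `O=c1[nH]/c(=N\OCCCc2cccc(F)c2)ccn1[C@@H]1O[C@H](COP(=O)(O)OP(=O)(O)OP(=O)(O)O)[C@@H](O)[C@H]1O` share a core and differ in the group carried on the chain. Going by the values given here, in a functional assay on 1321-N1 cells for agonist activity at P2Y purinoceptor 6 (Homo sapiens), read by scintillation counting and inositol phosphate accumulation (a higher number here means that more compound is needed for the effect, a lower number that less compound is needed), compound 1 gives 1780 nM, and compound 2 gives 539 nM; the change a 3.3-fold lower number from compound 1 to compound 2 (0.52 log units; beyond the scatter) places compound 2 at the lower of the two numbers so far. Compound 3 `O=c1[nH]/c(=N\OCCCc2ccc([N+](=O)[O-])cc2)ccn1[C@@H]1O[C@H](COP(=O)(O)OP(=O)(O)OP(=O)(O)O)[C@@H](O)[C@H]1O` keeps the chain of compound 2 and alters only the ring at its end: 4-nitrophenyl in place of 3-fluorophenyl on a saturated chain carbon, three bonds along the chain from an oxygen. Among the compounds with values here, no measured step tests such an exchange of one ring substituent for another; the single step available, a 3.3-fold lower number from compound 1 to compound 2 (0.52 log units; beyond the scatter), concerns the linking chain rather than the ring, so it offers no direction for this one. Compound 3 is therefore expected to stay near compound 2 in this assay, with an estimated 1.2-fold higher number from compound 2 to compound 3 (0.08 log units; within the scatter) that need not exceed the scatter. The estimate for compound 3 is 650 nM, within 200 nM to 2200 nM.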

Compound 3, half-maximal effective concentration: 1330 nM
Compound 3: middle estimate off by 2.0-fold (0.31 log units), on the low side; measured number inside the range.
By their numbers in this assay, from the lowest: compound 2; then compounds 3 and 1 (each within the scatter of the next).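

In this assay, the ring at the end of the chain proves to matter: 4-nitrophenyl in place of 3-fluorophenyl gives a 2.5-fold higher number from compound 2 to compound 3 (0.39 log units; beyond the scatter), so a change confined to the ring can move the number beyond the scatter. With 4-nitrobenzyl in place of phenoxy the result is a 1.3-fold lower number from compound 1 to compound 3 (0.13 log units; within the scatter), within the scatter, so the gain seen earlier with 3-fluorobenzyl does not carry over to every substituted benzyl group on this chain. Nothing available explains the difference between the two rings.

The exchange alters both the group and its place on the ring, so the effects of the two remain unseparated; 4-fluorophenyl or 3-nitrophenyl would pull them apart. Also open, going by these compounds, is how an unsubstituted phenyl, a ring bearing an amine or a carboxylic acid, or a longer chain would read here.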